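One added methyl on a well-tolerated compound

A few compounds are considered here, and "the series" means these few. Any claim that something is new, unique, unknown or untested is made for them only; others in the source may bear on it.

- compound 1 `CN(C)c1nc(Cc2c(F)cccc2F)cc(=O)[nH]1`: > 94000 nM
- compound 2 `CC1CCCN(c2nc(Cc3c(F)cccc3F)cc(=O)[nH]2)C1`: > 78000 nM
- compound 3 `CC(c1cc(=O)[nH]c(N(C)C)n1)c1c(F)cccc1F`: not yet measured

In an ADME assay on MT4 cells (Homo sapiens) for cytotoxicity, read by MTT assay, with a stated time of 4 days (a higher number here means that more compound is tolerated, a lower number that less compound is tolerated), compound 1 gives > 94000 nM, which is a limit and not a number. Compound 2 gives > 78000 nM, which is also a limit. Compound 3 differs from compound 1 by methyl in place of hydrogen on a saturated chain carbon bound to two aromatic carbons. Within the data shown here, the only measured step, a step that the two limits leave unreadable from compound 1 to compound 2, lies at another place and offers no size to carry over. No step beyond the scatter is therefore expected in this assay, and a limit is the likely result. The expected change is an at least 1.0-fold lower number from compound 1 to compound 3 (0.02 log units; that floor lies within the scatter). Compound 3 is estimated at 89000 nM, with an expected range of 40000 nM to 120000 nM.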

Compound 3, half-maximal cytotoxic concentration: 89000 nM
Compound 3: the middle estimate sits on the measured number at the digits printed, within the range that was stated.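

In this assay, among these compounds, compound 3 gives 89000 nM, the only value shown that is a number and not a limit. Methyl in place of hydrogen on this saturated chain carbon gives an at least 1.0-fold lower number from compound 1 to compound 3 (0.02 log units; that floor lies within the scatter), so a methyl here brings no readable loss of tolerance. The true size of the step stays unknown, because compound 1 stands at a limit of the assay: the limit of > 94000 nM in this assay, at which 1 of the 3 values shown sits.

From the compounds shown here alone, whether a longer chain such as ethyl, or a hydroxyl group, would be tolerated equally well on this carbon remains open. So does whether this methyl would behave the same way with the 3-methylpiperidin-1-yl group of compound 2 in place of dimethylamino.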